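Replacing the 4-nitrophenyl group of compound 2

The source may hold more compounds than are shown below. What is called first, only, known or untested is meant among the compounds shown, and "the series" means these compounds.

In a physicochemical assay for solubility, read by spectrophotometry, in phosphate buffer, with a stated time of 18 h, at pH 7.4 (a higher number here means a more soluble compound, a lower number a less soluble compound), two compounds built on one shared core have been measured. Compound 1 `Cc1ccc(-c2nc3c(c(C)nn3-c3ccccc3)c(-c3ccccc3O)c2C#N)cc1` gives 26000 nM. Compound 2 `Cc1nn(-c2ccccc2)c2nc(-c3ccc([N+](=O)[O-])cc3)c(C#N)c(-c3ccccc3O)c12` gives 6000 nM, the lower of the two numbers. Compound 3 `Cc1nn(-c2ccccc2)c2nc(-c3ccc4c(c3)OCCO4)c(C#N)c(-c3ccccc3O)c12` has not yet been measured. It carries 2,3-dihydro-1,4-benzodioxin-6-yl in place of 4-nitrophenyl on an aromatic carbon, next to the ring nitrogen and ortho to a cyano group (2,3-dihydro-1,4-benzodioxin-6-yl in place of 4-nitrophenyl on an aromatic carbon).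

Among the compounds with values here, only one measured step bears on this change: a 4.3-fold lower number from compound 1 to compound 2 (0.64 log units; beyond the scatter), a modest step beyond the scatter, with nitro in place of methyl on an aromatic carbon. With the nitro group gone, compound 3 is expected to move part of the way back toward compound 1 at 26000 nM in this assay, by a modest step upward no larger than that one. Within the data shown here, no measured compound carries the 2,3-dihydro-1,4-benzodioxin-6-yl group, so the range stays wide and includes no change at all. The estimate amounts to a 1.7-fold higher number from compound 2 to compound 3 (0.22 log units; within the scatter), an expected modest rise. For compound 3 the expected value is 10000 nM, with an estimated range from 3500 nM to 28000 nM.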

Compound 3, solubility: 11000 nM
Compound 3: the middle estimate sits 1.1-fold (0.04 log units) below what was measured, and the stated range covers the measured number.
By their numbers in this assay, from the lowest: compounds 2 and 3 (each within the scatter of the next); then compound 1.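

In this assay the exchange on this aromatic carbon, next to the ring nitrogen and ortho to a cyano group, amounts to a 1.8-fold higher number from compound 2 to compound 3 (0.26 log units; within the scatter) and thus does not separate compound 2 from compound 3. Measured against the 4-methylphenyl group, the 2,3-dihydro-1,4-benzodioxin-6-yl group gives a 2.4-fold lower number from compound 1 to compound 3 (0.37 log units; beyond the scatter) and this shows what the first pair could not: the gap from compound 1 is not confined to the compound carrying the nitro group, since compound 2 and compound 3 both stand apart from it by steps beyond the scatter. Nothing measured here accounts for these numbers.

The compounds shown leave open how an unsubstituted phenyl, a 4-methoxyphenyl with only one of the two ring oxygens, or a phenyl bearing an amine or a carboxylic acid would read at this position. They also leave open whether the same order of these three groups would hold if the 2-hydroxyphenyl group on the shared core were replaced by another group.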